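This account rests on a few compounds, and the source may have more. Where it says the series, first, only, none or still open, it means among the compounds named here.

The measured compounds, each with its value in a functional assay on HeLa cells (Homo sapiens) for cytotoxicity, read by CCK-8 assay, with a stated time of 72 h; on this read-out lower numbers stand for stronger inhibition and higher numbers for weaker inhibition:
compound 1, `C=CCn1c(=O)/c(=C\c2cc(Br)ccc2F)[nH]c(=O)/c1=C\c1ccccc1OC`, 34600 nM;
compound 2, `C=CCn1c(=O)/c(=C\c2ccccc2OC)[nH]c(=O)/c1=C\c1ccccc1OC`, 6900 nM;
compound 3, `C=CCn1c(=O)/c(=C\c2ccccc2C(F)(F)F)[nH]c(=O)/c1=C\c1ccccc1OC`, 4600 nM.

Compound 3 gives the lowest of the three numbers; compound 2 sits within the scatter of it, while compound 1 lies clearly higher. Compound 4, `C=CCn1c(=O)/c(=C\c2ccc(F)c(Br)c2)[nH]c(=O)/c1=C\c1ccccc1OC`, differs from compound 3 by 3-bromo-4-fluorophenyl in place of 2-(trifluoromethyl)phenyl on a double-bonded chain carbon bound to an aromatic carbon. The step that bears most directly is a 7.5-fold lower number from compound 1 to compound 3 (0.88 log units; beyond the scatter), which moved from 5-bromo-2-fluorophenyl to 2-(trifluoromethyl)phenyl; a 5.0-fold lower number from compound 1 to compound 2 (0.70 log units; beyond the scatter) pointed the same way. Since compound 4 returns to a bromine-and-fluorine ring, its number in this assay is expected to rise again, by a 4.3-fold higher number from compound 3 to compound 4 (0.64 log units; beyond the scatter), probably beyond the scatter. Compound 4 is estimated at 20000 nM, with a range from 6000 nM to 60000 nM.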

Compound 4, half-maximal inhibitory concentration: "not active" (no number reported)
For compound 4 the study gives words and no number; no gap can be computed for the estimate.
By their numbers in this assay, from the lowest: compounds 3 and 2 (each within the scatter of the next); then compound 1.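

Compound 4 is reported in this assay as "not active" without a number, so no new step can be read against compound 3 or any other compound. No measured evidence bears on this result. The compounds shown leave open how far the placement of bromine and fluorine on this ring governs cytotoxicity.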